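Swapping the trifluoromethyl-bearing ring for a plain benzyl

A few compounds are considered here, and "the series" means these few. Any claim that something is new, unique, unknown or untested is made for them only; others in the source may bear on it.

Measured so far in an ADME assay on HepG2 cells (Homo sapiens) for cytotoxicity, read by luminescence, CellTiter-Glo and ATP content, with a stated time of 72 h; a higher number here means that more compound is needed for the effect, a lower number that less compound is needed:
compound 1 `COc1ccc(F)cc1CNCCCNc1ccnc2cc(Cc3ccc(C#N)cc3)ccc12`, 6050 nM;
compound 2 `COc1ccc(F)cc1CNCCCNc1ccnc2cc(Oc3cccc(N(C)C)c3)ccc12`, 3300 nM;
compound 3 `COc1ccc(F)cc1CNCCCNc1ccnc2cc(Cc3cccc(C(F)(F)F)c3)ccc12`, 440 nM.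

Compound 3 gives the lowest of the three numbers, with compound 2 nearest and compound 1 furthest, both beyond the scatter. Compound 4 `COc1ccc(F)cc1CNCCCNc1ccnc2cc(CCc3ccccc3)ccc12` is not yet measured; it differs from compound 3 by benzyl in place of 3-(trifluoromethyl)phenyl on a saturated chain carbon bound to an aromatic carbon. Going by the values given here, two measured steps bear on this: a 14-fold lower number from compound 1 to compound 3 (1.14 log units; beyond the scatter) and a 7.5-fold lower number from compound 2 to compound 3 (0.88 log units; beyond the scatter). Both show that arriving at the 3-(trifluoromethyl)phenyl group in compound 3 brought the number down sharply, so leaving it is expected to push the number back up, toward compounds 1 and 2. The step of a 4.5-fold higher number from compound 3 to compound 4 (0.66 log units; beyond the scatter) is therefore expected to be a higher number, beyond the scatter. Compound 4 is estimated at 2000 nM, within 700 nM to 6000 nM.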

Compound 4, half-maximal effective concentration: 4240 nM
Compound 4: the middle estimate sits 2.1-fold (0.33 log units) below what was measured; the range from low to high includes it.
By their numbers in this assay, from the lowest: compound 3; then compounds 2, 4 and 1 (each within the scatter of the next).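

In this assay, the phenethyl group of compound 4 does not keep the low number of compound 3, with a 9.6-fold higher number from compound 3 to compound 4 (0.98 log units; beyond the scatter). Instead it falls level with the other two compounds, with a 1.3-fold higher number from compound 2 to compound 4 (0.11 log units; within the scatter) and a 1.4-fold lower number from compound 1 to compound 4 (0.15 log units; within the scatter), so among these four groups only 3-(trifluoromethyl)benzyl stands apart. Nothing measured here accounts for that gap.

The compounds shown leave open whether the low number of compound 3 follows the trifluoromethyl group or the benzyl link, since both change together in this step. A 3-(trifluoromethyl)phenethyl group would separate the two.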